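A few compounds are considered here, and "the series" means these few. Any claim that something is new, unique, unknown or untested is made for them only; others in the source may bear on it.

Measured values in an ADME assay on HEK293 cells (Homo sapiens) for cytotoxicity, with a stated time of 6 h (on this read-out lower numbers stand for higher toxicity in this test and higher numbers for lower toxicity in this test), are as follows

Compound 1 `CCCCCNc1nc(N)nc2ccccc12` gives > 25000 nM
Compound 2 `CCCCNc1nc(N)nc2cc(C(=O)N(C)C)ccc12` gives > 18000 nM
Compound 3 `CCCCNc1nc(N)nc2cccc(C)c12` gives > 25000 nM

Each of these three entries is a limit of the assay and not a number. Compound 3 stands at > 25000 nM as a limit, so it has no number that would place it on the scale.

Compound 4 `CCCCNc1nc(N)nc2cccc(OCCOC)c12` carries 2-methoxyethoxy in place of methyl on an aromatic carbon. Within the data shown here, no step between measured compounds is available, so the data give no direct measure of what such a change does in this assay on this series. What is expected is no step beyond the scatter, in either direction. The estimated step is a number no higher from compound 3 to compound 4 (the limit leaves the size open) and it stays within that scatter. Compound 4 is also expected to be reported as a limit rather than a number, as all three measured compounds are. The estimated value for compound 4 is 25000 nM with an expected range from 12000 nM to 50000 nM overall.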

Compound 4, half-maximal cytotoxic concentration: 10000 nM
Estimate against measurement, compound 4: 2.5-fold (0.40 log units) above; measured number below the stated range.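

In this assay, putting 2-methoxyethoxy in place of methyl on an aromatic carbon gives an at least 2.5-fold lower number from compound 3 to compound 4 (0.39 log units; beyond the scatter), so a change at this position can move the read-out beyond the scatter. Compound 4 is the only compound shown with a number on the scale, and it gives the one real value of the series in this test. The other three compounds are reported only as limits of the assay: the limit of > 25000 nM in this assay, at which 2 of the 4 values shown sit.

What the compounds shown leave open is whether the lower number goes with the ether oxygens or with the length of the chain, as neither a plain methoxy nor an all-carbon butyl group appears at this position. Also open, on these data alone, is how a chain ending in an amine, or a carboxylic acid, would read at the same place.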